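The source may hold more compounds than are shown below. What is called first, only, known or untested is meant among the compounds shown, and "the series" means these compounds.

In a functional assay on RS4-11 cells (Homo sapiens) for inhibition, read by CCK-8 assay, with a stated time of 48 h (on this read-out lower numbers stand for stronger inhibition and higher numbers for weaker inhibition), compound 1 `O=C(NCCNS(=O)(=O)c1ccc(-c2ccccc2O[C@H]2CC[C@@H](O)CC2)s1)Nc1ccc([N+](=O)[O-])cc1` gives 12400 nM. Compound 2 `COc1ccc(NC(=O)NCCNS(=O)(=O)c2sccc2-c2ccc(C)cc2Oc2ccc(O)c(O)c2)cc1` gives 8200 nM, which lies within the usual scatter of the value for compound 1, so the two numbers cannot be told apart. Compound 3 `Cc1ccc(-c2ccsc2S(=O)(=O)NCCNC(=S)Nc2ccc([N+](=O)[O-])cc2)c(Oc2ccc(O)c(O)c2)c1` keeps the core of compound 2 and differs in one group on an amine nitrogen: a group of 12 heavy atoms (7 carbon, 2 nitrogen, 2 oxygen, 1 sulfur; one six-membered aromatic ring of carbon only) in place of a group of 11 heavy atoms (8 carbon, 1 nitrogen, 2 oxygen; one six-membered aromatic ring of carbon only), on an amine nitrogen. Among the compounds with values here, no measured pair of compounds isolates this kind of change, so no effect beyond the scatter is expected. The estimated step is a 1.3-fold lower number from compound 2 to compound 3 (0.10 log units; within the scatter). For compound 3, the expected value is 6500 nM, with an estimated range from 2000 nM to 18000 nM.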

Compound 3, half-maximal inhibitory concentration: 5100 nM
Beside the measured number, compound 3's estimate is 1.3-fold (0.11 log units) above it; the measured number falls inside the stated range.
By their numbers in this assay, from the lowest: compounds 3, 2 and 1 (each within the scatter of the next, the first and the last beyond it).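

Replacing (4-methoxyphenyl)carbamoyl on an amine nitrogen with the sulfur-containing group of 12 heavy atoms gives a 1.6-fold lower number from compound 2 to compound 3 (0.21 log units; within the scatter) in this assay. This first single-place comparison shows that this position tolerates this exchange, with no effect that can be separated from the scatter. Nothing measured here bears on the reason for this result. The exchange alters the group in more than one way, so the contribution of each part remains unresolved. Also open, going by these compounds, is whether a smaller acetyl group, or a group carrying an amine or carboxylic acid, would move the number beyond the scatter.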